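A few compounds are considered here, and "the series" means these few. Any claim that something is new, unique, unknown or untested is made for them only; others in the source may bear on it.

Compound 1 `O=C(CCCCCCc1nc(-c2ccccc2Cl)no1)NO` and compound 2 `Nc1ccccc1NC(=O)CCCCCCc1nc(-c2ccccc2)no1` carry the same chain on the same shared core and differ only in the group at the far end of that chain. In an assay on isolated protein for inhibition of histone deacetylase 8 (Homo sapiens), read by fluorescence, with a stated time of 10 min (on this read-out lower numbers stand for stronger inhibition and higher numbers for weaker inhibition), compound 1 gives 3650 nM. In this assay compound 2 reaches only a limit, > 10000 nM. That is the point at which (the limit of > 10000 nM in this assay, at which 1 of the 2 values shown sits). Compound 3 `Nc1ccccc1NC(=O)CCCCCCc1nc(-c2cccc([N+](=O)[O-])c2)no1` differs from compound 2 by nitro in place of hydrogen on an aromatic carbon. Among the measured compounds shown here, no measured pair here shows how such a change moves inhibition, so a step of no more than the usual scatter is expected, a step that the limit leaves unreadable from compound 2 to compound 3. Compound 3 is accordingly expected at 12000 nM, between 3000 nM and 40000 nM.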

Compound 3, half-maximal inhibitory concentration: > 10000 nM
Compound 3 was reported as a limit; the forecaster's own chance of this, stated with the estimate: 60%; the middle value does not contradict the limit.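

No step can be read between compound 2 and compound 3, because both are reported only as limits: the limit of > 10000 nM in this assay, at which 2 of the 3 values shown sit.

The compounds shown leave open how nitro in place of hydrogen on an aromatic carbon moves inhibition.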